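Halogen positions swapped: expectation for compound 3

The compounds below may be only part of what the source reports. "The series", "measured", "known", "first", "only" and "open" are said of these compounds alone.

Measured in an ADME assay on microsomes from liver (Homo sapiens) for metabolic stability, tested at 2.5 uM; a lower number here means slower removal, a higher number faster removal of the compound:
Compound 1 `Fc1ccc(-c2ccc(Cn3nnc4ccccc43)cc2)c(F)c1` gives 0.9 mL/min/g.
Compound 2 `Fc1cc(Cl)ccc1-c1ccc(Cn2nnc3ccccc32)cc1` gives 0.4 mL/min/g.

Compound 2 holds the lower of the two numbers in this assay. Within the data shown here, the only measured step is a 2.3-fold lower number from compound 1 to compound 2 (0.35 log units; beyond the scatter). Compound 3 `Fc1ccc(-c2ccc(Cn3nnc4ccccc43)cc2)c(Cl)c1` differs from compound 2 by 2-chloro-4-fluorophenyl in place of 4-chloro-2-fluorophenyl on an aromatic carbon. Among the measured compounds shown here, no measured step exchanges the positions of the two halogens, so the single step is an indirect guide only; both compounds 2 and 3 carry one chloro and one fluoro on that ring. Compound 3 is therefore expected to stay near compound 2, with at most a small change, a 1.5-fold higher number from compound 2 to compound 3 (0.18 log units; within the scatter), and an estimate of 0.6 mL/min/g within 0.3 mL/min/g to 1.2 mL/min/g.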

Compound 3, intrinsic clearance in a liver preparation (reported as CLH), per the amount of preparation that the assay uses: 0.7 mL/min/g
Compound 3: middle estimate off by 1.2-fold (0.07 log units), on the low side; low and high end bracket the measured number.
By their numbers in this assay, from the lowest: compounds 2, 3 and 1 (each within the scatter of the next, the first and the last beyond it).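

In this assay swapping the two halogens gives a 1.8-fold higher number from compound 2 to compound 3 (0.24 log units; within the scatter) and so does not separate 4-chloro-2-fluorophenyl from 2-chloro-4-fluorophenyl on this aromatic carbon. Of the two exchanges of fluoro for chloro, a 2.3-fold lower number from compound 1 to compound 2 (0.35 log units; beyond the scatter) stands beyond the scatter and a 1.3-fold lower number from compound 1 to compound 3 (0.11 log units; within the scatter) does not, so only the first of these separates its pair. No evidence on hand bears on why the numbers fall this way.

Open, as far as these compounds go, is whether a nitrile or a methoxy group on this ring would stay near compound 2 in this read-out. Also open, from the compounds shown here alone, is how any change to the shared core would read.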